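Series notes: ring-opened chromone chalcones, the aryl tail

A few compounds are considered here, and "the series" means these few. Any claim that something is new, unique, unknown or untested is made for them only; others in the source may bear on it.

Compound 1 `COc1ccc(C(=O)/C=C/c2ccc(N(C)C)cc2)c2c1C=CC(C)(C)O2` is the reference point of this set. Going by the values given here, in a functional assay on HepG2 cells (Homo sapiens) for antiproliferative activity, read by MTT assay, with a stated time of 24 h (a higher number here means a weaker inhibitor, a lower number a stronger inhibitor), compound 1 gives 730 nM, and it is the only compound with a numerical result. Compound 2 `COc1ccc(C(=O)/C=C/c2ccc(N(c3ccccc3)c3ccccc3)cc2)c2c1C=CC(C)(C)O2` gives only a limit in this assay, > 10000 nM. Compound 3 `COc1ccc(C(=O)/C=C/c2ccc(C(F)(F)F)cc2)c2c1C=CC(C)(C)O2` likewise gives only a limit in this assay, > 10000 nM. Among the compounds with values here, the one step that can be sized, an at least 13-fold higher number from compound 1 to compound 3 (1.13 log units; beyond the scatter), is the replacement of the dimethylamino group and is large. Compound 4 `COc1ccc(C(=O)/C=C/c2ccccc2Cl)c2c1C=CC(C)(C)O2` is not yet measured. It differs from compound 1 by 2-chlorophenyl in place of 4-(dimethylamino)phenyl on a double-bonded chain carbon bound to a double-bonded chain carbon. The 4-(dimethylamino)phenyl leaves here as well, so the step to compound 3 is the closest measured guide, and the reading is shaped by the limit of > 10000 nM in this assay, at which 2 of the 3 values shown sit, since every departure from the dimethylamino group so far has ended at that limit. The step of an 11-fold higher number from compound 1 to compound 4 (1.04 log units; beyond the scatter) is therefore expected to be a large one toward weaker inhibition, with the outcome most likely sitting at or close to the limit. For compound 4 the estimate in this assay is 8000 nM, with a range from 2500 nM to 12000 nM.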

Compound 4, half-maximal inhibitory concentration: > 10000 nM
Compound 4 was reported as a limit; the forecaster's own chance of this, stated with the estimate: 55%; middle value at least 1.2-fold (0.09 log units) from the limit.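

The 2-chlorophenyl tail gives an at least 13-fold higher number from compound 1 to compound 4 (1.13 log units; beyond the scatter), a second sizable step in this assay and the first that brings in a chlorine and removes the nitrogen of the tail without putting trifluoromethyl in its place. The finding is thus no longer tied to one replacement: among the four compounds shown, only compound 1, with 4-(dimethylamino)phenyl, gives a numerical result, and no compound shown goes against this. The size of the new step is only a lower bound, and compound 2, compound 3 and compound 4 cannot be ranked, as each value is a limit and not a number, so the steps among them cannot be read: the limit of > 10000 nM in this assay, at which 3 of the 4 values shown sit.

The compounds shown leave open whether the numerical result depends on dimethylamino itself or would survive with a close relative such as diethylamino, pyrrolidine, morpholine or a primary amine. They also leave open whether a non-amine tail such as methoxy or hydroxyl, or an unsubstituted phenyl, would give a number in this assay, and whether chlorine would do so in another place on the ring.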